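The source may hold more compounds than are shown below. What is called first, only, known or untested is meant among the compounds shown, and "the series" means these compounds.

Two compounds of the series carry a reading in an assay on isolated protein for inhibition of long-chain fatty acid transport protein 1 (Mus musculus); a higher number here means a weaker inhibitor, a lower number a stronger inhibitor. Among the measured compounds shown here, compound 1 `CCn1c(CNc2ccccc2)nnc1SCc1nc2cc(C(=O)C(C)C)ccc2o1` gives 520 nM in this assay, the only number so far. For compound 2 `CCn1c(CNc2ccccc2)nnc1SCC(=O)Nc1ccc(C(=O)NC)cc1` the reading is a limit of this assay, > 10000 nM (the limit of > 10000 nM in this assay, at which 1 of the 2 values shown sits), so no number sits beside compound 1. Compound 3 `CCn1c(CNc2ccccc2)nnc1SCc1nc2cc(C)ccc2o1` is not yet measured; it differs from compound 1 by methyl in place of isopropylcarbonyl on an aromatic carbon. For the measured compounds named here, no measured step covers this change. The expected step from compound 1 to compound 3 is a 2.9-fold higher number from compound 1 to compound 3 (0.46 log units; beyond the scatter), toward a weaker inhibitor, beyond the scatter. Compound 3 is estimated at 1500 nM in this assay, in a range from 500 nM to 5000 nM.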

Compound 3, half-maximal inhibitory concentration: > 10000 nM
Compound 3: a limit, no number (the forecaster's own chance of this, stated with the estimate: 15%); at least 6.6-fold (0.82 log units) between middle value and limit.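

Methyl in place of isopropylcarbonyl on this aromatic carbon gives an at least 19-fold higher number from compound 1 to compound 3 (1.28 log units; beyond the scatter), so this single change is enough to lose a measurable reading in this assay. On these data alone, the reading for compound 3 is a limit and not a number, so the full size of the step stays unknown. Of the two groups seen at this carbon, only isopropylcarbonyl gives a number, and readings now gather at the limit: the limit of > 10000 nM in this assay, at which 2 of the 3 values shown sit.

As far as these compounds go, it remains open whether the carbonyl or the isopropyl part matters. An acetyl group, an isopropyl group or a carboxylic acid at this carbon would separate these.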